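The source may hold more compounds than are shown below. What is called first, only, known or untested is meant among the compounds shown, and "the series" means these compounds.

Measured compounds in a functional assay on MDA-MB-231 cells (Homo sapiens) for antiproliferative activity, read by MTT assay, with a stated time of 24 h; a higher number here means a weaker inhibitor, a lower number a stronger inhibitor:

Compound 1 `COc1ccc(-c2cc(/C=C/C(=O)c3ccc(Cl)cc3)nc3cc(-c4ccccc4)nn23)cc1OC` gives 17100 nM.
Compound 2 `COc1ccc(/C=C/C(=O)c2cc(-c3ccc(OC)c(OC)c3)n3nc(-c4ccccc4)cc3n2)cc1` gives 22000 nM.
Compound 3 `COc1ccc(-c2cc(C(=O)/C=C/c3ccccc3)nc3cc(-c4ccccc4)nn23)cc1OC` gives 23300 nM.

Compound 1 has the lowest of the three numbers, yet the steps of a 1.3-fold higher number from compound 1 to compound 2 (0.11 log units; within the scatter) and a 1.4-fold higher number from compound 1 to compound 3 (0.13 log units; within the scatter) both fall within the scatter, so the three compounds cannot be ranked against one another on these data.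

Compound 4 `COc1cc(-c2cc(/C=C/C(=O)c3ccc(Cl)cc3)nc3cc(-c4ccccc4)nn23)cc(OC)c1OC` is compound 1 with one change: methoxy in place of hydrogen on an aromatic carbon. Among the measured compounds shown here, no measured pair carries exactly this change on this ring. For the measured compounds named here, the only step involving a methoxy group, a 1.1-fold higher number from compound 2 to compound 3 (0.02 log units; within the scatter), concerns a different ring and stays within the scatter. With every measured step within the scatter, there is no ground to expect compound 4 to move beyond it, so the expected step is a 1.1-fold lower number from compound 1 to compound 4 (0.03 log units; within the scatter), meaning no real change. Compound 4 is therefore estimated at 16000 nM in this assay, with an expected range of 7000 nM to 36000 nM.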

Compound 4, half-maximal inhibitory concentration: 32500 nM
Estimate against measurement, compound 4: 2.0-fold (0.31 log units) below, within the range that was stated.
By their numbers in this assay, from the lowest: compounds 1, 2, 3 and 4 (each within the scatter of the next).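

Among the compounds shown here, replacing 3,4-dimethoxyphenyl with 3,4,5-trimethoxyphenyl gives the first measured step on this ring, and in this assay that step is a 1.9-fold higher number from compound 1 to compound 4 (0.28 log units; within the scatter) so this added methoxy, ortho to a methoxy group, brings no change that can be told apart from repeat measurements. The earlier compounds shown here showed this exchange of hydrogen and methoxy only on a different ring, and it now stands on two cores, with neither step nor the gap between them going beyond the scatter: the same change on two cores in this assay, a 1.1-fold higher number (0.02 log units; within the scatter) from compound 2 to compound 3 and a 1.9-fold lower number (0.28 log units; within the scatter) from compound 4 to compound 1, 2.0-fold (0.30 log units) apart, within the scatter of two such steps.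

Hydrogen and methoxy are the only groups shown at this position, so whether a hydroxyl, a fluorine or an amine there would shift the number beyond the scatter remains open. On these data alone, a longer chain such as ethoxy in place of the added methoxy is equally open.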